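The source may report more compounds than this note shows. Statements on the series, on what has been measured and on what is new or still open speak of the compounds shown alone.

Series notes. Compound 1 `Cc1cc(C)cc(S(=O)(=O)n2c(SCC(=O)Nc3ccccc3Br)nc3ccccc32)c1` carries the shared core with a 2-bromophenyl group on the amide-type nitrogen. In an ADME assay on MT4 cells (Homo sapiens) for cytotoxicity (a lower number here means that less compound is tolerated, a higher number that more compound is tolerated), compound 1 reaches only a limit, >= 235000 nM. Compound 2 `Cc1cc(C)cc(S(=O)(=O)n2c(SCC(=O)Nc3ccccc3Br)nc3ccc(Cl)cc32)c1` differs from compound 1 by chloro in place of hydrogen on an aromatic carbon. In this assay compound 2 gives 145000 nM. The step is an at least 1.6-fold lower number from compound 1 to compound 2 (0.20 log units; that floor lies within the scatter). Compound 3 `Cc1cc(C)cc(S(=O)(=O)n2c(SCC(=O)Nc3ccc(S(C)(=O)=O)cc3Cl)nc3ccccc32)c1` differs from compound 1 by 2-chloro-4-(methylsulfonyl)phenyl in place of 2-bromophenyl on an amide-type nitrogen. In this assay compound 3 also stops at a limit, > 221000 nM. Compound 3 sits at the limit of > 221000 nM in this assay, at which 1 of the 3 values shown sits. Compound 1 sits at the limit of >= 235000 nM in this assay, at which 1 of the 3 values shown sits. The step that the two limits leave unreadable from compound 1 to compound 3 is thus unreadable. Compound 4 `Cc1cc(C)cc(S(=O)(=O)n2c(SCC(=O)Nc3ccc(S(C)(=O)=O)cc3Cl)nc3ccc(Cl)cc32)c1` is not yet measured; it differs from compound 3 by chloro in place of hydrogen on an aromatic carbon, the same change as between compound 1 and compound 2, in the same place. Carrying over the measured step of an at least 1.6-fold lower number from compound 1 to compound 2 (0.20 log units; that floor lies within the scatter), an expected step of an at least 1.4-fold lower number from compound 3 to compound 4 (0.16 log units; that floor lies within the scatter) is estimated for compound 4. The estimated value of compound 4 in this assay is 150000 nM, expected to fall between 80000 nM and 300000 nM.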

Compound 4, half-maximal cytotoxic concentration: 3590 nM
Compound 4: middle estimate off by 42-fold (1.62 log units), on the high side; the whole stated range lies above it.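

In this assay, chloro in place of hydrogen on an aromatic carbon gives an at least 61-fold lower number from compound 3 to compound 4 (1.78 log units; beyond the scatter), and with that chloro already present, the 2-chloro-4-(methylsulfonyl)phenyl change gives a 40-fold lower number from compound 2 to compound 4 (1.61 log units; beyond the scatter). The chloro steps on the two cores stand side by side as floors only: the same change on two cores in this assay, an at least 1.6-fold lower number (0.20 log units; that floor lies within the scatter) from compound 1 to compound 2 and an at least 61-fold lower number (1.78 log units; beyond the scatter) from compound 3 to compound 4; the limit leaves it open whether they differ. The change can therefore accompany a large step on one core, but the step on the core of compound 1 gives no reliable guide to the size on another core, and no true size or difference in size can be stated.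

Open, going by these compounds, is whether the large drop requires chloro and the 2-chloro-4-(methylsulfonyl)phenyl group together. Also open, on these data alone, is whether fluoro or an amine on that aromatic carbon would give a similar step.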